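Swapping the Amide Aryl Group on a Shared Core

The source may report more compounds than this note shows. Statements on the series, on what has been measured and on what is new or still open speak of the compounds shown alone.

Compound 1, `O=C(Nc1ccc(Cl)c(-c2nnc3c(Cl)cccn23)c1)c1ccc(F)cc1Cl`: > 100000 nM
Compound 2, `O=C(Nc1ccc(Cl)c(-c2nnc3c(Cl)cccn23)c1)c1cccc(Cl)c1`: 52700 nM

Of the compounds shown here, two have been measured in a functional assay on A549 cells (Homo sapiens) for antiproliferative activity, read by MTT assay, with a stated time of 72 h; a higher number here means a weaker inhibitor, a lower number a stronger inhibitor. Compound 1 `O=C(Nc1ccc(Cl)c(-c2nnc3c(Cl)cccn23)c1)c1ccc(F)cc1Cl` reaches only the limit of the assay, giving > 100000 nM, which is a limit and not a number. Compound 2 `O=C(Nc1ccc(Cl)c(-c2nnc3c(Cl)cccn23)c1)c1cccc(Cl)c1` gives 52700 nM in this assay. Within the data shown here, the single measured step, an at least 1.8-fold lower number from compound 1 to compound 2 (0.27 log units; that floor lies within the scatter), has a floor that lies within the scatter, so it shows at most a modest gain. Compound 2 therefore holds the only number shown, the other value being a limit (the limit of > 100000 nM in this assay, at which 1 of the 2 values shown sits).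

Compound 3 `O=C(Nc1ccc(Cl)c(-c2nnc3c(Cl)cccn23)c1)c1c(F)cccc1Cl` differs from compound 2 in one place: 2-chloro-6-fluorophenyl in place of 3-chlorophenyl on a carbonyl carbon. Among the measured compounds shown here, the only step that bears on this change is an at least 1.8-fold lower number from compound 1 to compound 2 (0.27 log units; that floor lies within the scatter), in which a 2-chloro-4-fluorophenyl group gave way to 3-chlorophenyl and the value moved from a limit to a number. The new change moves back toward a group of the kind seen in compound 1, so a weaker result is expected, with the step of a 1.9-fold higher number from compound 2 to compound 3 (0.28 log units; within the scatter) judged from that one comparison. Compound 3 is estimated at 100000 nM, within 40000 nM to 300000 nM, and may again return only a limit.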

Compound 3, half-maximal inhibitory concentration: 72300 nM
Compound 3: the middle estimate sits 1.4-fold (0.14 log units) above what was measured; the measured number falls inside the stated range.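

Replacing 3-chlorophenyl with 2-chloro-6-fluorophenyl on the carbonyl carbon adds a fluorine, yet this assay shows no real separation between the two groups, with a 1.4-fold higher number from compound 2 to compound 3 (0.14 log units; within the scatter). Set against the 2-chloro-4-fluorophenyl group, which holds the same atoms, the 2-chloro-6-fluorophenyl group gives an at least 1.3-fold lower number from compound 1 to compound 3 (0.14 log units; that floor lies within the scatter), so this comparison does not separate those two groups either, and compound 3 does show that a chlorine and a fluorine on this ring can still return a real number. The value of compound 1 is a limit and not a number, so its comparison rests only on a floor: the limit of > 100000 nM in this assay, at which 1 of the 3 values shown sits.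

No step among these compounds is shown beyond the scatter, so the three halogen-bearing phenyl groups cannot be ranked at this position. On these data alone, it remains open whether a different kind of group on the carbonyl carbon, such as an unsubstituted phenyl, a methoxy-bearing phenyl, a phenyl carrying an amine or a carboxylic acid, or a longer chain, would move the value beyond the scatter in this assay.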